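Hydrogen for methoxy on the aromatic ring

The source may report more compounds than this note shows. Statements on the series, on what has been measured and on what is new or still open speak of the compounds shown alone.

compound 1 `COc1cccc(C=C2C(=O)N(c3ccc(Cl)cc3)N(c3ccc(Cl)cc3)C2=O)c1O` gives 24300 nM
compound 2 `COc1ccccc1C=C1C(=O)N(c2ccc(Cl)cc2)N(c2ccc(Cl)cc2)C1=O` gives 28600 nM

Within the data shown here, in a functional assay on MGC-803 cells (Homo sapiens) for cytotoxicity, read by MTT assay, with a stated time of 72 h (on this read-out higher numbers stand for weaker inhibition and lower numbers for stronger inhibition), compound 2 lies within the scatter of compound 1, the only other measured compound, so the two cannot be ordered. Compound 3 `O=C1C(=Cc2ccccc2)C(=O)N(c2ccc(Cl)cc2)N1c1ccc(Cl)cc1` differs from compound 2 by hydrogen in place of methoxy on an aromatic carbon, ortho to a large group (hydrogen in place of methoxy on an aromatic carbon). Among the measured compounds shown here, one measured step bears on this change: a 1.2-fold higher number from compound 1 to compound 2 (0.07 log units; within the scatter) is small and also alters the substituents on this aromatic ring. It is a single step, and it does not remove the methoxy lost here, so it is thin evidence. No shift beyond the scatter is therefore expected in this assay, and no direction is favoured. The expected step is a 1.0-fold lower number from compound 2 to compound 3 (0.01 log units; within the scatter) on this estimate. For compound 3 the estimate is 28000 nM with an expected range from 12000 nM to 60000 nM in this read-out.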

Compound 3, half-maximal inhibitory concentration: 27200 nM
Beside the measured number, compound 3's estimate is 1.0-fold (0.01 log units) above it; the range from low to high includes it.
By their numbers in this assay, from the lowest: compounds 1, 3 and 2 (each within the scatter of the next).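

In this assay hydrogen in place of methoxy on an aromatic carbon, ortho to a large group, gives a 1.1-fold lower number from compound 2 to compound 3 (0.02 log units; within the scatter) and so shows that this methoxy can go without a shift beyond the scatter. Phenyl in place of 2-hydroxy-3-methoxyphenyl gives a 1.1-fold higher number from compound 1 to compound 3 (0.05 log units; within the scatter) and extends that reading to the fully bare ring, which the earlier pair could not show, as compound 2 still kept a methoxy. No measurement at hand accounts for this result.

Whether any group on this ring can move the number beyond the scatter stays open, as the compounds shown carry only hydrogen, methoxy and hydroxy there. An amine, a carboxylic acid or a longer chain in place of the methoxy would test that, and the same question stands for the rest of the shared core.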